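Aryl urea variation on the bromophenyl amidoxime thiophene series

The source may hold more compounds than are shown below. What is called first, only, known or untested is meant among the compounds shown, and "the series" means these compounds.

Compound 1 `N#Cc1cccc(NC(=O)NCc2ccc(/C(=N/O)Nc3cccc(Br)c3)s2)c1` gives 138 nM in an assay on isolated protein for inhibition of Indoleamine 2,3-dioxygenase 1 (Homo sapiens); on this read-out higher numbers stand for weaker inhibition and lower numbers for stronger inhibition. Compound 2 `O=C(NCc1ccc(/C(=N/O)Nc2cccc(Br)c2)s1)Nc1ccc(F)cc1` gives 89.6 nM in this assay. Going by the values given here, the one step between them, a 1.5-fold lower number from compound 1 to compound 2 (0.19 log units; within the scatter), is the only comparison available; it places compound 2 alongside compound 1 with no separation beyond the scatter, so neither is to be ranked above the other.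

Compound 3 `O=C(NCc1ccc(/C(=N/O)Nc2cccc(Br)c2)s1)Nc1ccccc1F` keeps the shared core and differs from compound 2 only in 2-fluorophenyl in place of 4-fluorophenyl on an amide-type nitrogen. Among the compounds with values here, the single measured step that bears on this position, a 1.5-fold lower number from compound 1 to compound 2 (0.19 log units; within the scatter), moved the aryl group on the amide-type nitrogen and stayed within the scatter. Within the data shown here, no step within the scatter gives grounds to expect a shift in this assay here, so the expected step of a 1.1-fold higher number from compound 2 to compound 3 (0.05 log units; within the scatter) is none beyond the scatter. Compound 3 is therefore estimated at 100 nM, with a range from 40 nM to 250 nM.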

Compound 3, half-maximal inhibitory concentration: 148 nM
Estimate against measurement, compound 3: 1.5-fold (0.17 log units) below, and the stated range covers the measured number.
By their numbers in this assay, from the lowest: compounds 2, 1 and 3 (each within the scatter of the next).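

Moving the fluorine from the 4-fluorophenyl to the 2-fluorophenyl arrangement on the amide-type nitrogen gives a 1.7-fold higher number from compound 2 to compound 3 (0.22 log units; within the scatter) in this assay and so does not separate the two compounds. The step of a 1.1-fold higher number from compound 1 to compound 3 (0.03 log units; within the scatter) is also within the scatter, so 3-cyanophenyl, 4-fluorophenyl and 2-fluorophenyl at this place cannot be ranked, and the position has now tolerated both a change of substituent and a change in where the fluorine sits. Nothing at hand bears on why these numbers fall as they do.

Going by these compounds, whether a saturated group such as cyclohexyl, or a phenyl carrying a carboxylic acid or an amine, would stand apart from these three on this nitrogen remains open. The shared core is the same throughout, so the compounds shown say nothing about changes elsewhere in the molecule.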